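This account rests on a few compounds, and the source may have more. Where it says the series, first, only, none or still open, it means among the compounds named here.

Going by the values given here, compound 2 `Cc1cc(O)c(C2=NN(c3ccc(S(N)(=O)=O)cc3)C(/C=C/c3ccccc3)C2)cc1Cl` gives 53000 nM in a functional assay on NCI/ADR-RES cells (Homo sapiens) for antiproliferative activity, with a stated time of 48 h (a higher number here means that more compound is tolerated, a lower number that less compound is tolerated), and stands with the highest of the two numbers measured so far; its nearest neighbour is compound 1 `Cc1cc(O)c(C2=NN(c3ccc(S(N)(=O)=O)cc3)C(c3ccccc3Cl)C2)cc1Cl`, which gives 38800 nM in this assay. Among the compounds with values here, the one step measured on the series, a 1.4-fold higher number from compound 1 to compound 2 (0.14 log units; within the scatter), stays within the scatter. Compound 3 `COc1ccc(C2CC(c3cc(Cl)c(C)cc3O)=NN2c2ccc(S(N)(=O)=O)cc2)c(OC)c1OC` differs from compound 2 by 2,3,4-trimethoxyphenyl in place of 2-phenylethenyl on a saturated ring carbon. Within the data shown here, no measured step exchanges one aryl group for another on that carbon, so the change from compound 2 to compound 3 is expected to stay within the scatter, a 1.2-fold lower number from compound 2 to compound 3 (0.07 log units; within the scatter). For compound 3 in this assay the estimate is 45000 nM, with a range from 15000 nM to 140000 nM.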

Compound 3, concentration lethal to 50% of the cells: > 100000 nM
Compound 3 ended at the assay's limit (the forecaster's own chance of this, stated with the estimate: 10%); middle value at least 2.2-fold (0.34 log units) away from the limit.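

Compound 3 is the only compound shown that reaches a limit rather than a number in this assay: the limit of > 100000 nM in this assay, at which 1 of the 3 values shown sits.

Going by these compounds alone, with 2,3,4-trimethoxyphenyl on this saturated ring carbon, the data give an at least 2.5-fold higher number from compound 1 to compound 3 (0.41 log units; beyond the scatter), the only step at this position that clears the scatter. The comparison with 2-phenylethenyl gives only a floor, an at least 1.8-fold higher number from compound 2 to compound 3 (0.27 log units; that floor lies within the scatter).

On these data alone, how far beyond the limit compound 3 lies stays open, as does whether the three methoxy groups matter individually. As far as these compounds go, what a single methoxy group, an amine or a carboxylic acid would give on this carbon also stays open.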